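The compounds below may be only part of what the source reports. "The series", "measured", "known", "first", "only" and "open" are said of these compounds alone.

Measured compounds:
compound 1, `CC(C)(C)O/N=C1\CN2CC[C@@H](c3ccc(Cl)cc3)C1C2`: 641 nM
compound 2, `Clc1ccc([C@@H]2CCN3C/C(=N\OCCCc4ccccc4)C2C3)cc1`: 53 nM
compound 3, `CN1CCC(c2ccc(Cl)cc2)C(C(=O)OCCCc2ccccc2)C1`: 1490 nM

In an assay for binding affinity to sodium-dependent dopamine transporter (Rattus norvegicus) (on this read-out lower numbers stand for stronger inhibition and higher numbers for weaker inhibition), compound 3 gives the highest number of the three; compound 1 lies nearest to it, compound 2 furthest away, and both of those gaps are beyond the scatter. Compound 4, `CN1CCC(c2ccc(Cl)cc2)C(C(=O)OCCCCCc2ccccc2)C1`, differs from compound 3 in one place: phenethyl in place of phenyl on a saturated chain carbon, three bonds along the chain from an oxygen next to a carbonyl group. Going by the values given here, no pair of measured compounds shows this change, so its effect is not known from the present data. The step from compound 3 to compound 4 is expected to be small, a 1.5-fold lower number from compound 3 to compound 4 (0.17 log units; within the scatter), most likely not beyond the scatter, with a slight lean toward a lower number. Compound 4 is therefore estimated at 1000 nM, with a range from 300 nM to 3500 nM.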

Compound 4, inhibition constant: 52 nM
Compound 4: middle estimate off by 19-fold (1.28 log units), on the high side; measured number below the stated range.
By their numbers in this assay, from the lowest: compounds 4 and 2 (each within the scatter of the next); then compound 1; then compound 3.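

In this assay, the place three bonds along the chain from an oxygen next to a carbonyl group proves highly responsive: phenethyl in place of phenyl gives a 29-fold lower number from compound 3 to compound 4 (1.46 log units; beyond the scatter) and is a large step. Going by these compounds alone, the length of this chain, with the same aromatic ring at its end, therefore matters in this assay, which the earlier compounds could not show because none of them differed in one place. On these data alone, whether a longer chain would lower the number further, or an amine within the chain would keep the gain, remains open. Nothing available here accounts for the size of this step.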